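A few compounds are considered here, and "the series" means these few. Any claim that something is new, unique, unknown or untested is made for them only; others in the source may bear on it.

Measured so far in a functional assay on RAW264.7 cells (Mus musculus) for inhibition, read by Griess assay, with stated times of 2 h and 24 h; on this read-out lower numbers stand for stronger inhibition and higher numbers for weaker inhibition:

- compound 1, `COc1ccc([C@@H]2CC(=O)c3c(O)cc(OCc4cn(Cc5cccc(Cl)c5)nn4)cc3O2)cc1O`, 18200 nM
- compound 2, `COc1ccc([C@@H]2CC(=O)c3c(O)cc(OCc4cn(Cc5ccc(Cl)cc5)nn4)cc3O2)cc1O`, 17800 nM
- compound 3, `COc1ccc([C@@H]2CC(=O)c3c(O)cc(OCc4cn(Cc5cccc(C(F)(F)F)c5)nn4)cc3O2)cc1O`, 19900 nM

Compound 1 stands second highest of the three numbers, but all three sit within the scatter of one another: the step of a 1.0-fold lower number from compound 1 to compound 2 (0.01 log units; within the scatter), the step of a 1.1-fold higher number from compound 1 to compound 3 (0.04 log units; within the scatter) and the step of a 1.1-fold higher number from compound 2 to compound 3 (0.05 log units; within the scatter) are each too small to read as a change. Across these three compounds the aryl group on the saturated chain carbon bound to the aromatic nitrogen was exchanged without the read-out moving.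

Compound 4, `CCn1cc(COc2cc(O)c3c(c2)O[C@H](c2ccc(OC)c(O)c2)CC3=O)nn1`, has not yet been measured. It differs from compound 1 as follows: methyl in place of 3-chlorophenyl on a saturated chain carbon bound to an aromatic nitrogen. For the measured compounds named here, no measured step covers a removal of the whole aryl group; the measured steps only swap one aryl for another and were all within the scatter. They therefore argue that the aryl portion is not strongly read by this assay, but a step from an aromatic ring to methyl is larger than any tested, so a shift beyond the scatter cannot be ruled out, and if one occurs a higher number is somewhat more likely than a lower one. The estimate for compound 4 is 24000 nM with a range from 11000 nM to 55000 nM, which means an expected step of a 1.3-fold higher number from compound 1 to compound 4 (0.12 log units; within the scatter).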

Compound 4, half-maximal inhibitory concentration: 15000 nM
Compound 4: the middle estimate sits 1.6-fold (0.20 log units) above what was measured; low and high end bracket the measured number.
By their numbers in this assay, from the lowest: compounds 4, 2, 1 and 3 (each within the scatter of the next).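

In this assay, replacing the whole aryl portion with methyl, read one bond further out as 3-chlorobenzyl to ethyl, gives a 1.2-fold lower number from compound 1 to compound 4 (0.08 log units; within the scatter) and, from the other two aryl compounds, a 1.2-fold lower number from compound 2 to compound 4 (0.07 log units; within the scatter) and a 1.3-fold lower number from compound 3 to compound 4 (0.12 log units; within the scatter), with all three steps within the scatter. The earlier steps shown here only exchanged one aryl group for another, whereas these show that the read-out on a saturated chain carbon bound to an aromatic nitrogen holds at the same level without any aromatic ring there, so neither the ring nor its chloro or trifluoromethyl group is required for the activity seen. Nothing available here explains why the read-out stays flat at this position.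

Still open is whether an amine, a carboxylic acid or a longer chain at this place would shift the number beyond the scatter, as the four compounds shown carry only ethyl or substituted benzyl groups there. Also open, from the compounds shown here alone, is what the shared core contributes to the read-out: all four compounds carry it unchanged.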